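Replacing 3,4-dimethoxyphenyl with 3,4-dihydroxyphenyl

This account rests on a few compounds, and the source may have more. Where it says the series, first, only, none or still open, it means among the compounds named here.

Compound 1 (`O=C(Nc1cccc([N+](=O)[O-])c1)N1CCN(S(=O)(=O)c2sccc2-c2ccccc2Oc2ccc(O)c(O)c2)CC1`) and compound 2 (`COc1ccc(Oc2ccccc2-c2ccsc2S(=O)(=O)N2CCN(C(=O)Nc3ccc([N+](=O)[O-])cc3)CC2)cc1OC`) were both tested in a functional assay on HeLa cells (Homo sapiens) for inhibition, read by CCK-8 assay, with a stated time of 48 h (on this read-out lower numbers stand for stronger inhibition and higher numbers for weaker inhibition), and neither returned a number. Compound 1 gives > 20000 nM as a limit of the assay. Compound 2 gives > 50000 nM as a limit as well, so compound 2 stands without a measured value. Compound 3 (`O=C(Nc1ccc([N+](=O)[O-])cc1)N1CCN(S(=O)(=O)c2sccc2-c2ccccc2Oc2ccc(O)c(O)c2)CC1`) differs from compound 2 in carrying 3,4-dihydroxyphenyl in place of 3,4-dimethoxyphenyl on an oxygen on an aromatic ring. Within the data shown here, no measured step shows what this change does in this assay, so the expectation is tentative: a modest move towards stronger inhibition, though one within the scatter is also possible. The estimate corresponds to an expected step of an at least 3.3-fold lower number from compound 2 to compound 3 (0.52 log units; beyond the scatter) in this direction. Compound 3 is expected to give about 15000 nM (estimated range 4000 nM to 50000 nM).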

Compound 3, half-maximal inhibitory concentration: > 20000 nM
Compound 3: no number, only a limit (the forecaster's own chance of this, stated with the estimate: 55%); middle value at least 1.3-fold (0.12 log units) away from the limit.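

In this assay compound 3 gives > 20000 nM, which is a limit and not a number, so its steps from compound 1 and from compound 2 cannot be read. The compounds shown leave open how strongly any of the three inhibits and what either change does.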